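The source may hold more compounds than are shown below. What is called first, only, known or untested is meant among the compounds shown, and "the series" means these compounds.

Measured compounds: compound 1 `C#CCN(c1ncccn1)c1nc2ccccc2s1` gives 18300 nM; compound 2 `FC(F)(F)Oc1ccc(-c2cc(CN(c3ncccn3)c3nc4ccccc4s3)on2)cc1` gives 14800 nM; compound 3 `COc1cc(-c2cc(CN(c3ncccn3)c3nc4ccccc4s3)on2)cc(OC)c1OC` gives 13400 nM.

All three numbers come from a functional assay on MCF7 cells (Homo sapiens) for antiproliferative activity, read by MTT assay; on this read-out lower numbers stand for stronger inhibition and higher numbers for weaker inhibition. Compound 2 stands second highest of the three. Its nearest neighbour is compound 3, whose value lies within the scatter of repeated measurements, and the furthest is compound 1, which also lies within that scatter. The three measured compounds are therefore indistinguishable on this read-out, and nothing here separates the propargyl group of compound 1 from the two aryl-isoxazolylmethyl groups on the shared core.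

Compound 4 `Fc1ccccc1-c1cc(CN(c2ncccn2)c2nc3ccccc3s2)on1` is the next member of the series. It differs from compound 2 in one place: 2-fluorophenyl in place of 4-(trifluoromethoxy)phenyl on an aromatic carbon. Going by the values given here, no step between two measured compounds that differ only in the aryl group has been recorded, so the size of this change in this assay is unknown. Given that compounds 1, 2 and 3 all sit close together despite their different substituents, the expectation is that the step from compound 2 to compound 4 will be none beyond the scatter, in either direction. Compound 4 is accordingly estimated at 15000 nM, with a range from 6000 nM to 40000 nM, an expected change of a 1.0-fold higher number from compound 2 to compound 4 (0.01 log units; within the scatter).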

Compound 4, half-maximal inhibitory concentration: 19500 nM
Compound 4: the middle estimate sits 1.3-fold (0.11 log units) below what was measured, within the range that was stated.
By their numbers in this assay, from the lowest: compounds 3, 2, 1 and 4 (each within the scatter of the next).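

In this assay, going by these compounds alone, putting 2-fluorophenyl in place of 4-(trifluoromethoxy)phenyl, on the aromatic carbon next to the ring nitrogen of the five-membered ring, gives a 1.3-fold higher number from compound 2 to compound 4 (0.12 log units; within the scatter), the first step here that isolates a single change at this position. The read-out therefore does not register this exchange, even though the two aryl groups differ in their heavy atoms, in the place of their substituent on the phenyl ring and in their hydrogen-bond acceptors. No measurement shown gives any reason for this lack of response.

Because both groups are substituted phenyl rings and the step alters the substituent and its place together, the compounds shown do not separate these two changes, which a 4-fluorophenyl group could begin to do. As far as these compounds go, it also remains open whether a group of another kind at this position, such as a phenyl ring bearing an amine or a carboxylic acid, or a longer alkyl chain in place of the aryl group, would move the number beyond the scatter.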